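Pyrrolidin-1-yl Replaces Dipropylamino in a Well-Tolerated Series

The source may report more compounds than this note shows. Statements on the series, on what has been measured and on what is new or still open speak of the compounds shown alone.

In an ADME assay on MT4 cells (Homo sapiens) for cytotoxicity, read by MTT assay, with a stated time of 4 days (a lower number here means that less compound is tolerated, a higher number that more compound is tolerated), compound 1 `CCCN(C)c1nc(Cc2c(F)cccc2F)cc(=O)[nH]1` gives 85000 nM. Compound 2 `CCCN(CCC)c1nc(Cc2c(F)cccc2F)cc(=O)[nH]1` gives only > 78000 nM, which is a limit of the assay and not a number. Compound 3 `O=c1cc(Cc2c(F)cccc2F)nc(N2CCCC2)[nH]1` has pyrrolidin-1-yl in place of dipropylamino on an aromatic carbon, a place between two ring nitrogen atoms: pyrrolidin-1-yl in place of dipropylamino on an aromatic carbon. Among the compounds with values here, only one measured step bears on this change, a step that the limit leaves unreadable from compound 1 to compound 2, which also alters the group at this place but has no readable size. With no measured size to carry over, no change beyond the usual scatter is expected in this assay, and no direction can be favoured. The expected change is a step that the limit leaves unreadable from compound 2 to compound 3. Compound 3 is estimated at 80000 nM, with an expected range of 35000 nM to 180000 nM.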

Compound 3, half-maximal cytotoxic concentration: > 86000 nM
Compound 3: a limit, no number; the forecaster's own chance of this, stated with the estimate: 50%; middle value at least 1.0-fold (0.03 log units) from the limit.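

In this assay compound 3 gives > 86000 nM, which is a limit of the assay and not a number. The step from dipropylamino to pyrrolidin-1-yl cannot be read, since both ends are limits, but with pyrrolidin-1-yl in place of methyl(propyl)amino the data give an at least 1.0-fold higher number from compound 1 to compound 3 (0.00 log units; that floor lies within the scatter). Within the data shown here, this place on the aromatic carbon, between two ring nitrogen atoms, therefore carries a five-membered non-aromatic ring as well as open chains, with no sign that less compound is tolerated.

From the compounds shown here alone, how far the true values of compound 2 and compound 3 lie past their limits remains open. Also open, going by these compounds, is what a piperidin-1-yl or morpholin-4-yl group at this place would give in this assay.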